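This account rests on a few compounds, and the source may have more. Where it says the series, first, only, none or still open, it means among the compounds named here.

In a functional assay on the whole organism for inhibition, with Felis catus as the target, with a stated time of 30 min (on this read-out lower numbers stand for an effect already at smaller amounts and higher numbers for an effect only at larger amounts of compound), compound 1 (`Cc1ccccc1OCCNCC(O)COc1ccccc1`) gives 0.031 mg/kg, and compound 3 (`Oc1ccc(OCC(O)CNCCOc2ccccc2)cc1`) stands level with it at 0.031 mg/kg, together the lowest of the three numbers. Compound 2 (`COc1ccccc1OCCNCC(O)COc1ccccc1`) gives 0.063 mg/kg. Methoxy in place of methyl on an aromatic carbon is a 2.0-fold higher number from compound 1 to compound 2 (0.31 log units; beyond the scatter). Compound 4 (`COCCNCC(O)COc1ccccc1`) has methyl in place of 2-methylphenyl on an oxygen on a saturated carbon. Going by the values given here, the only measured step that bears on this is the modest one above, and it leaves the aromatic ring in place. Among the compounds with values here, no measured compound lacks that ring, so the size rests on thin evidence. A larger step towards a higher number is expected in this assay, an estimated 8.1-fold higher number from compound 1 to compound 4 (0.91 log units; beyond the scatter). For compound 4 the expected value is 0.25 mg/kg, with an estimated range of 0.06 mg/kg to 1 mg/kg.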

Compound 4, dose for half-maximal effect: 0.13 mg/kg
The estimate for compound 4 lay 1.9-fold (0.28 log units) above the measured number; the range from low to high includes it.
By their numbers in this assay, from the lowest: compounds 1 and 3 (each within the scatter of the next); then compound 2; then compound 4.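

With methyl in place of 2-methylphenyl on an oxygen on a saturated carbon, this assay shows a 4.2-fold higher number from compound 1 to compound 4 (0.62 log units; beyond the scatter), the first read on removing the aromatic ring at this position. The ring is not required for an effect here: compound 4, with no ring at this place, still gives 0.13 mg/kg, though the change moves the number beyond the scatter. Nothing available accounts for the size of this step. Open, going by these compounds, is whether a cyclohexyl group or a longer alkyl chain on this oxygen would bring the number back towards that of compound 1.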